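The source may hold more compounds than are shown below. What is called first, only, known or untested is meant among the compounds shown, and "the series" means these compounds.

Compound 1, `CCCCN(O)C(=O)Nc1cc([C@@H]2CC[C@@H](c3cc(OC)c(OC)c(OC)c3)O2)cc(OC)c1OCCSc1ccc(Br)cc1`: 21 nM
Compound 2, `CCCCN(O)C(=O)Nc1cc([C@@H]2CC[C@@H](c3cc(OC)c(OC)c(OC)c3)O2)cc(OC)c1OCCSc1ccc(Cl)cc1`: 20 nM
Compound 3, `CCCCN(O)C(=O)NCc1cc([C@@H]2CC[C@@H](c3cc(OC)c(OC)c(OC)c3)O2)cc(OC)c1OCCSc1ccc(Cl)cc1`: 167 nM

Of the compounds shown here, three with a shared core have been tested in an assay for displacement of a labelled ligand from platelet-activating factor receptor (Homo sapiens); on this read-out lower numbers stand for stronger inhibition and higher numbers for weaker inhibition. Compound 2 gives the lowest of the three numbers. The nearest neighbour is found through the step of a 1.1-fold lower number from compound 1 to compound 2 (0.02 log units; within the scatter), a swap of one halogen for another that stayed within the scatter. The furthest neighbour is reached through the step of an 8.4-fold higher number from compound 2 to compound 3 (0.92 log units; beyond the scatter), where a methylene was inserted between the core and the hydroxyurea group.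

Compound 4, `CCCCN(O)C(=O)Nc1cc([C@@H]2CC[C@@H](c3cc(OC)c(OC)c(OC)c3)O2)cc(OC)c1OCCSc1cccc(Br)c1`, has not yet been measured. It differs from compound 2 in one place: 3-bromophenyl in place of 4-chlorophenyl on a sulfur. For the measured compounds named here, of the measured steps, only the step of a 1.1-fold lower number from compound 1 to compound 2 (0.02 log units; within the scatter) bears on this change, since it also exchanges bromo for chloro on the same phenyl ring, and it produced no shift beyond the scatter. Going by the values given here, no measured pair contains a 3-bromophenyl group, so the effect of that arrangement is untested. Compound 4 is therefore expected to show a step of a 1.5-fold higher number from compound 2 to compound 4 (0.18 log units; within the scatter) in this assay, with wide uncertainty. The estimate for compound 4 is 30 nM, within a range from 10 nM to 90 nM.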

Compound 4, half-maximal inhibitory concentration: 22 nM
For compound 4 the middle estimate is 1.4-fold (0.13 log units) above the measured one; the range from low to high includes it.
By their numbers in this assay, from the lowest: compounds 2, 1 and 4 (each within the scatter of the next); then compound 3.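

In this assay, the comparison of 3-bromophenyl with 4-bromophenyl on a sulfur gives a 1.0-fold higher number from compound 1 to compound 4 (0.02 log units; within the scatter). The earlier compounds shown here varied only the halogen on a 4-substituted phenyl ring, whereas this pair tests where the bromine sits on that ring, and the two placements cannot be told apart in this assay. The step that alters both the halogen and its placement, a 1.1-fold higher number from compound 2 to compound 4 (0.04 log units; within the scatter), also stays within the scatter, though no measurement here explains this tolerance.

The compounds shown leave open whether the halogen is needed at all, as a plain phenyl ring or one carrying a methoxy group could show. They also leave open whether a carboxylic acid on the ring, or a butyl chain in place of the ring, would fit as well.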